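Swapping the aryl group on the shared core: solubility

This account rests on a few compounds, and the source may have more. Where it says the series, first, only, none or still open, it means among the compounds named here.

Within the data shown here, compound 2 `Cc1cc(NCc2ccccn2)n2ncc(-c3ccncc3)c2n1` carries the shared core with a pyridin-4-yl group; in a physicochemical assay for solubility, read by HPLC, using the shake flask method, measured as kinetic solubility, with a stated time of 2 h, at pH 7.4 (on this read-out lower numbers stand for lower solubility and higher numbers for higher solubility), compound 2 gives 161000 nM, the only plain number among the two values shown. Compound 1 `Cc1cc(NCc2ccccn2)n2ncc(-c3c(C)cccc3C)c2n1` is the other measured compound. In this assay compound 1 gives < 5000 nM, which is a limit of the assay rather than a number, as described in the limit of < 5000 nM in this assay, at which 1 of the 2 values shown sits. Among the measured compounds shown here, the one measured step, an at least 32-fold higher number from compound 1 to compound 2 (1.50 log units; beyond the scatter), links the two. Compound 3 `Cc1cc(NCc2ccccn2)n2ncc(-c3cccc(N)c3)c2n1` has not been measured in this assay. The change from compound 2 to compound 3 is 3-aminophenyl in place of pyridin-4-yl on an aromatic carbon. No measured step carries this exact change, and the one step shown concerns a different replacement at the same position, so it bears on the question only loosely. Compound 3 is therefore expected to give a number somewhat lower than compound 2, with the step of a 3.2-fold lower number from compound 2 to compound 3 (0.51 log units; beyond the scatter) estimated to reach beyond the scatter but to stay far from the limit. Compound 3 is estimated at 50000 nM, within the range 10000 nM to 160000 nM.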

Compound 3, solubility: 160000 nM
Estimate against measurement, compound 3: 3.2-fold (0.51 log units) below; measured number inside the range.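

In this assay, the new step, a 1.0-fold lower number from compound 2 to compound 3 (0.00 log units; within the scatter), shows that 3-aminophenyl and pyridin-4-yl cannot be told apart at this position, on an aromatic carbon of a five-membered aromatic ring with 2 nitrogen. A ring of carbon only therefore does not by itself give a low reading here, and compound 1, which also carries a ring of carbon only, is the one compound shown at the low end. The second new step, an at least 32-fold higher number from compound 1 to compound 3 (1.50 log units; beyond the scatter), gives only a bound on its size, because the value of compound 1 is a limit of the assay and not a number: the limit of < 5000 nM in this assay, at which 1 of the 3 values shown sits.

The compounds shown do not separate the part played by the amine of 3-aminophenyl from that of the ring it sits on, nor do they say how much of the gap to compound 1 belongs to the two methyl groups of 2,6-dimethylphenyl. An unsubstituted phenyl group at this position, or a phenyl ring carrying a hydroxyl or a carboxylic acid, would speak to both questions.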